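Chloro for methylsulfanyl on a purinoceptor ligand core

The source may report more compounds than this note shows. Statements on the series, on what has been measured and on what is new or still open speak of the compounds shown alone.

Measured compounds:
compound 1 `CSc1nc(N)c2ncn(C3C(O)C(O)[C@@]4(COP(=O)(O)OP(=O)(O)OP(=O)(O)O)C[C@@H]34)c2n1` gives 3.7 nM in an assay on cell membranes for activation of P2Y purinoceptor 1 (Meleagris gallopavo); on this read-out higher numbers stand for an effect only at larger amounts of compound and lower numbers for an effect already at smaller amounts
compound 2 `CSc1nc(N)c2ncn([C@H]3[C@H](O)[C@H](O)[C@@]4(COP(=O)(O)O)C[C@@H]34)c2n1` gives 1190 nM in this assay
compound 3 `Nc1nc(Cl)nc2c1ncn2C1C(O)C(O)[C@@]2(COP(=O)(O)OP(=O)(O)OP(=O)(O)O)C[C@@H]12` gives 3 nM in this assay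

Compound 1 and compound 3 share a core and differ in one place: chloro in place of methylsulfanyl on an aromatic carbon. The step of a 1.2-fold lower number from compound 1 to compound 3 (0.09 log units; within the scatter) is within the usual scatter of repeated measurements, so the two values cannot be ordered against each other.

Compound 2 sits apart from both. Its value is the highest of the three, with compound 1 as the nearest and compound 3 as the furthest of its neighbours, both beyond the scatter. How the core of compound 2 differs from the core of compound 1 is not broken down here.

Compound 4 `Nc1nc(Cl)nc2c1ncn2[C@H]1[C@H](O)[C@H](O)[C@@]2(COP(=O)(O)O)C[C@@H]12` has not yet been measured. It is made from compound 2 by chloro in place of methylsulfanyl on an aromatic carbon, the same change as from compound 1 to compound 3, at a place described in the same words. The expectation for compound 4 rests on that earlier step: since the step of a 1.2-fold lower number from compound 1 to compound 3 (0.09 log units; within the scatter) stayed within the scatter on one core, the step of a 1.2-fold lower number from compound 2 to compound 4 (0.08 log units; within the scatter) is expected to be of about the same size on the core of compound 2, so that compound 4 is expected to remain near compound 2. Among the measured compounds shown here, the estimate for compound 4 is 1000 nM, with a range from 350 nM to 2800 nM; a second core is only one example, and the change has been seen twice in all, so the range is kept wide.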

Compound 4, half-maximal effective concentration: 3900 nM
The estimate for compound 4 lay 3.9-fold (0.59 log units) below the measured number, outside the stated range (above it).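

In this assay, chloro in place of methylsulfanyl on an aromatic carbon, between two ring nitrogen atoms, gave a 3.3-fold higher number from compound 2 to compound 4 (0.52 log units; beyond the scatter), and this step does not match the one seen earlier on the other core: the same change on two cores in this assay, a 1.2-fold lower number (0.09 log units; within the scatter) from compound 1 to compound 3 and a 3.3-fold higher number (0.52 log units; beyond the scatter) from compound 2 to compound 4, 4.0-fold (0.61 log units) apart, beyond the scatter of two such steps

The change therefore did not carry over in size from one core to the other in this series: it left no readable difference on the core of compound 1 but a modest one on the core of compound 2. This rests on just two pairs of compounds, and it does not show which difference between the two cores goes with the gap between the steps, nor how the same change would behave on a third core.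

The compounds shown hold only methylsulfanyl and chloro at this aromatic carbon, so it stays open whether a longer chain such as propylsulfanyl, or an amine, would also give steps that depend on the core. From the compounds shown here alone, it also stays open whether a core bearing a diphosphate chain would behave like the core of compound 1, like the core of compound 2, or like neither.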